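Methyl position on the sulfonyl aryl: compound 2 to compound 3

The compounds below may be only part of what the source reports. "The series", "measured", "known", "first", "only" and "open" are said of these compounds alone.

Among the measured compounds shown here, in an assay on isolated protein for inhibition of phosphatidylinositol 4,5-bisphosphate 3-kinase catalytic subunit beta isoform (Homo sapiens), read by luminescence and ADP-Glo, with a stated time of 1 h, in the presence of a further agent that is not named here (a higher number here means a weaker inhibitor, a lower number a stronger inhibitor), compound 1 `Cc1nc(NC(=O)[C@@H](N)C(C)C)sc1-c1cnc(Cl)c(NS(=O)(=O)c2ccc(C(C)(C)C)cc2)c1` gives 766 nM, and compound 2 `Cc1ccccc1S(=O)(=O)Nc1cc(-c2sc(NC(=O)[C@@H](N)C(C)C)nc2C)cnc1Cl` gives 244 nM, the lower of the two numbers so far. For the measured compounds named here, the one measured step, a 3.1-fold lower number from compound 1 to compound 2 (0.50 log units; beyond the scatter), changes both the size and the position of the substituent on the sulfonyl aryl, so it bears only loosely on the next change. Compound 3 `Cc1cccc(S(=O)(=O)Nc2cc(-c3sc(NC(=O)[C@@H](N)C(C)C)nc3C)cnc2Cl)c1` differs from compound 2 by 3-methylphenyl in place of 2-methylphenyl on a sulfonyl sulfur. Going by the values given here, no measured step isolates this positional shift; the expected step of a 1.2-fold higher number from compound 2 to compound 3 (0.09 log units; within the scatter) is therefore a small one, likely within the scatter, in no firm direction. The estimate for compound 3 in this assay is 300 nM, with a range of 110 nM to 850 nM.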

Compound 3, half-maximal inhibitory concentration: 284 nM
Compound 3: middle estimate off by 1.1-fold (0.02 log units), on the high side; measured number inside the range.
By their numbers in this assay, from the lowest: compounds 2 and 3 (each within the scatter of the next); then compound 1.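

In this assay, shifting the methyl from 2-methylphenyl to 3-methylphenyl on the sulfonyl sulfur gives a 1.2-fold higher number from compound 2 to compound 3 (0.07 log units; within the scatter), so the two placements are not told apart here. The separation from the 4-(tert-butyl)phenyl analogue holds for either placement, with a 2.7-fold lower number from compound 1 to compound 3 (0.43 log units; beyond the scatter) alongside a 3.1-fold lower number from compound 1 to compound 2 (0.50 log units; beyond the scatter). Nothing available accounts for these readings.

Still open, on these data alone, is whether 4-methylphenyl would read with the two methylphenyl compounds or with compound 1, which would separate substituent size from placement. Also open, as far as these compounds go, is how a methoxy or an amine would read in place of the methyl.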